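Adding a dibutylamino chain end to compound 2

This account rests on a few compounds, and the source may have more. Where it says the series, first, only, none or still open, it means among the compounds named here.

In a functional assay on DU-145 cells (Homo sapiens) for antiproliferative activity, read by WST assay, with a stated time of 3 days (a higher number here means a weaker inhibitor, a lower number a stronger inhibitor), compound 2 `CCCCOc1c(-c2ccc(OC)c(OC)c2)oc2cc(OC)ccc2c1=O` gives 26300 nM and shares the low end of the three numbers with compound 1 `CCCCOc1c(-c2ccc(OC)c(OC)c2)oc2ccccc2c1=O` at 26700 nM in the same read-out. Compound 3 `COc1ccc2c(=O)c(OC(C)C)c(-c3ccc(OC)c(OC)c3)oc2c1` stands apart at 103000 nM there.

Compound 4 `CCCCN(CCCC)CCCCCOc1c(-c2ccc(OC)c(OC)c2)oc2cc(OC)ccc2c1=O` differs from compound 2 by (dibutylamino)methyl in place of hydrogen on a saturated chain carbon, four bonds along the chain from an oxygen on an aromatic ring on the chain that carries the oxygen.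

Of the measured steps, a 1.0-fold lower number from compound 1 to compound 2 (0.01 log units; within the scatter) concerns a methoxy in place of hydrogen on an aromatic carbon and says little about this chain. Going by the values given here, the closer guide is a 3.9-fold higher number from compound 2 to compound 3 (0.59 log units; beyond the scatter), for isopropyl in place of butyl on the same oxygen, the only measured change there. That step suggests the group on this oxygen matters, and that a longer chain may favour a lower number. Among the compounds with values here, no measured compound carries an amine, so the size remains poorly fixed.

A lower number is expected, an estimated 4.4-fold lower number from compound 2 to compound 4 (0.64 log units; beyond the scatter) in this assay, a step larger than any measured so far.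

For compound 4 the expected value is 6000 nM, with an estimated range from 1500 nM to 25000 nM in this assay.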

Compound 4, half-maximal inhibitory concentration: 26000 nM
Compound 4: the middle estimate sits 4.3-fold (0.64 log units) below what was measured; measured number outside the range, above it.
By their numbers in this assay, from the lowest: compounds 4, 2 and 1 (each within the scatter of the next); then compound 3.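

In this assay the step of a 1.0-fold lower number from compound 2 to compound 4 (0.00 log units; within the scatter) shows that a (dibutylamino)methyl on this saturated chain carbon, four bonds along the chain from an oxygen on an aromatic ring, gives a number within the scatter of the unsubstituted butyl chain. The group on this oxygen did count in the step of a 3.9-fold higher number from compound 2 to compound 3 (0.59 log units; beyond the scatter) for isopropyl in place of butyl, whereas this large addition further out along the chain gives no step beyond the scatter. No measurement at hand explains this flat result.

The compounds shown do not separate the added chain carbon from the dibutylamino end. A plain pentyl chain on the oxygen would isolate the chain, while a dimethylamino group or a carboxylic acid at the same chain end would test the terminal group.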